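The compounds below may be only part of what the source reports. "The series", "measured", "known", "first", "only" and "open" are said of these compounds alone.

Compound 3 `C[C@H](Nc1nc(N)nc(N)c1C#N)c1cc2ccc(F)cn2c(=O)c1-c1ccccc1` gives 88% in an ADME assay on microsomes from liver (Rattus norvegicus), read by LC-MS, using NADPH, with a stated time of 30 min, tested at 1 uM; on this read-out higher numbers stand for a more stable compound and lower numbers for a less stable compound. Its number does not differ beyond the scatter from compound 1 `C[C@H](Nc1ncnc2[nH]cnc12)c1cc2ccccn2c(=O)c1-c1ccccc1`, which gives 93%, nor from compound 2 `C[C@H](Nc1ncnc2[nH]cnc12)c1cc2ccc(F)cn2c(=O)c1-c1ccccc1`, which gives 95%. The two measured steps were small: a number 2 percentage points higher from compound 1 to compound 2 (within the scatter), and a number 7 percentage points lower from compound 2 to compound 3 (within the scatter). Compound 4 `C[C@H](Nc1nc(N)ncc1C#N)c1cc2ccc(F)cn2c(=O)c1-c1ccccc1` differs from compound 3 by hydrogen in place of amino on an aromatic carbon. Going by the values given here, no measured step touches this change, so the expectation for compound 4 rests only on the flat run of the three numbers, which all sit high. Compound 4 is therefore expected to show no step beyond the scatter in this assay, no change at the digits printed from compound 3 to compound 4 (within the scatter). For compound 4 the estimated value is 88%, with a range from 76% to 97%.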

Compound 4, percent of the compound remaining: 74%
Compound 4: the middle estimate sits 14 percentage points above what was measured; the whole stated range lies above it.
By their numbers in this assay, from the lowest: compound 4; then compounds 3, 1 and 2 (each within the scatter of the next).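

In this assay, going by these compounds alone, the amino group on this carbon, ortho to a cyano group, proves to count: with hydrogen in its place the result is a number 14 percentage points lower from compound 3 to compound 4 (beyond the scatter), the first single-site change here to exceed the scatter. The 2-amino-5-cyanopyrimidin-4-yl group also falls clearly short of the original group on the amine nitrogen, with a number 21 percentage points lower from compound 2 to compound 4 (beyond the scatter), which the 2,6-diamino-5-cyanopyrimidin-4-yl group did not. No available evidence accounts for this drop. On these data alone, whether a methyl, methoxy or dimethylamino group at this carbon would behave like amino or like hydrogen remains open.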